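This account rests on a few compounds, and the source may have more. Where it says the series, first, only, none or still open, it means among the compounds named here.

Measured so far in an ADME assay on microsomes from liver (Homo sapiens) for metabolic stability, read by LC-MS, tested at 1 uM; on this read-out higher numbers stand for fast clearance and lower numbers for slow clearance:

compound 1 `CC(C)(O)CN1CCC(Oc2ccc([C@H]3CC[C@]4(CC3)OOC3(O4)C4CC5CC(C4)CC3C5)cc2)CC1`: 18 mL.min-1.g-1
compound 2 `NCCCOc1ccc([C@H]2CC[C@]3(CC2)OOC2(O3)C3CC4CC(C3)CC2C4)cc1`: < 7 mL.min-1.g-1, a limit of the assay, not a number

Compound 2 therefore stands at the floor of this assay. Within the data shown here, the one measured step, an at least 2.5-fold lower number from compound 1 to compound 2 (0.41 log units; beyond the scatter), is the only comparison on hand, and it ends at that floor, (the limit of < 7 mL.min-1.g-1 in this assay, at which 1 of the 2 values shown sits). Compound 3 `c1cc([C@H]2CC[C@]3(CC2)OOC2(O3)C3CC4CC(C3)CC2C4)ccc1OCCCNC1CCOCC1` differs from compound 2 by oxan-4-yl in place of hydrogen on an amine nitrogen. Among the measured compounds shown here, no measured step covers a change on the amine nitrogen, so the only guide is that compound 1, carrying a substituted amine nitrogen, gives 18 mL.min-1.g-1. A modest rise, an at least 1.7-fold higher number from compound 2 to compound 3 (0.23 log units; that floor lies within the scatter), is expected for compound 3, with an estimate of 12 mL.min-1.g-1 and a range of 7 mL.min-1.g-1 to 25 mL.min-1.g-1.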

Compound 3, intrinsic clearance in microsomes: 10 mL.min-1.g-1
Compound 3: middle estimate off by 1.2-fold (0.08 log units), on the high side; the range from low to high includes it.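

Oxan-4-yl on the amine nitrogen gives the first reading of a change at this position in this assay, with an at least 1.4-fold higher number from compound 2 to compound 3 (0.15 log units; that floor lies within the scatter). Compound 2 stands at a limit of the assay, not a number, so the true size of that step stays open: the limit of < 7 mL.min-1.g-1 in this assay, at which 1 of the 3 values shown sits.

The exchange of the whole group on the oxygen, a 1.8-fold lower number from compound 1 to compound 3 (0.26 log units; within the scatter), does not separate the 3-((oxan-4-yl)amino)propyl chain from the 1-(2-hydroxy-2-methylpropyl)piperidin-4-yl group.

Open, on these data alone, is where a methyl, an acetyl or a piperidin-4-yl on the amine nitrogen would fall relative to compound 2 and compound 3.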